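This account rests on a few compounds, and the source may have more. Where it says the series, first, only, none or still open, it means among the compounds named here.

In an assay on COS-7 cells for displacement of a labelled ligand from Endothelin receptor type B (Sus scrofa) (on this read-out higher numbers stand for weaker inhibition and lower numbers for stronger inhibition), compound 1, with structure `Cc1onc(NS(=O)(=O)c2ccc(N)cc2)c1I`, reaches only the limit > 1000000 nM, so for it there is a limit and no number. Compound 2, `COc1cccc(Sc2c(NS(=O)(=O)c3ccc(C(C)(C)C)cc3)noc2CCCC#N)c1`, gives 520 nM in this assay. Compound 3, `CSc1c(NS(=O)(=O)c2ccc(C(C)(C)C)cc2)noc1C`, gives 35000 nM in this assay. Of the two numbers shown, compound 2 has the lower one, and the gap between compound 2 and compound 3 lies beyond the usual scatter of repeated measurements. For the measured compounds named here, no pair of measured compounds here differs in one place only, so no single measured step is available as a guide.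

Compound 4, `COc1cccc(Sc2c(NS(=O)(=O)c3ccc(C(C)(C)C)cc3)noc2CCCC(C)=O)c1`, has not yet been measured. It differs from compound 2 in one place: acetyl in place of cyano on a saturated chain carbon, three bonds along the chain from an aromatic carbon. The rest of the molecule is unchanged. Going by the values given here, with no measured step of this kind to lean on, the expectation is a change that stays close to the scatter, with the number perhaps drifting slightly upward; the step from compound 2 to compound 4 is expected to read a 1.4-fold higher number from compound 2 to compound 4 (0.16 log units; within the scatter). Compound 4 is therefore expected to give about 750 nM in this assay, with a likely range from 250 nM to 2500 nM.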

Compound 4, half-maximal inhibitory concentration: 400 nM
For compound 4 the middle estimate is 1.9-fold (0.27 log units) above the measured one; low and high end bracket the measured number.
By their numbers in this assay, from the lowest: compounds 4 and 2 (each within the scatter of the next); then compound 3. At a limit, above all of these: compound 1.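

In this assay putting acetyl in place of cyano on a saturated chain carbon, three bonds along the chain from an aromatic carbon, gives a 1.3-fold lower number from compound 2 to compound 4 (0.11 log units; within the scatter) and so leaves the two compounds indistinguishable on this read-out. This is the first single change that can be read among the compounds shown, and it tells that this place takes 3-acetylpropyl as well as 3-cyanopropyl, with a carbonyl standing in for a nitrile and one more heavy atom in the group, without the reading moving beyond the scatter. Nothing measured here says why the two groups read alike.

Both groups are counted with one hydrogen-bond acceptor, no donors and no net charge, so the compounds shown leave open how this place would respond to an amine or a carboxylic acid on the same chain. A longer chain, or a chain with no group on it at all, also remains an open question, since only these two groups can be compared here.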